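The source may hold more compounds than are shown below. What is called first, only, known or untested is meant among the compounds shown, and "the series" means these compounds.

Working notes on the series, read in a physicochemical assay for lipophilicity, read by HPLC, measured as chromatographic lipophilicity, at pH 7.4; a lower number here means a more polar compound, a higher number a more lipophilic compound. Going by the values given here, compound 2 `O=C(c1cccnc1)N1N=CCC1c1ccccc1` gives 2.7, the lower of the two numbers so far. Among the compounds with values here, the only other reading comes from compound 1 `O=C(C1CCCC1)N1N=CCC1c1ccccc1`, at 5.4. The next structure is compound 3 `O=C(C1CCC1)N1N=CCC1c1ccccc1`, and the change is cyclobutyl in place of pyridin-3-yl on a carbonyl carbon. Within the data shown here, one measured step bears on this, a number 2.70 log units lower from compound 1 to compound 2 (beyond the scatter), which is large and beyond the scatter. It put pyridin-3-yl in place of cyclopentyl at that same place, so the new change runs the opposite way, with cyclobutyl instead of cyclopentyl as the carbon ring. A large upward move of a number 2.20 log units higher from compound 2 to compound 3 (beyond the scatter) is therefore expected in this assay, slightly short of the full measured step. The estimate for compound 3 is 4.9, with an expected range from 4.4 to 5.4.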

Compound 3, distribution coefficient: 4.7
Beside the measured number, compound 3's estimate is 0.20 log units above it, within the range that was stated.
By their numbers in this assay, from the lowest: compound 2; then compound 3; then compound 1.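

In this assay, cyclobutyl in place of pyridin-3-yl on the carbonyl carbon gives a number 2.00 log units higher from compound 2 to compound 3 (beyond the scatter), so the large gap to pyridin-3-yl is no longer tied to cyclopentyl alone: it now holds for two carbon-only rings. The carbon rings are not interchangeable at this position either, as cyclobutyl in place of cyclopentyl gives a number 0.70 log units lower from compound 1 to compound 3 (beyond the scatter), a modest step beside the large one. No supporting data on hand account for either step.

The compounds shown do not separate the ring nitrogen of pyridin-3-yl from its aromatic ring, a question that phenyl on this carbonyl carbon would address. On these data alone, how cyclopropyl, an open chain such as isopropyl, or a carbon ring bearing an amine would read at this place remains open.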